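This account rests on a few compounds, and the source may have more. Where it says the series, first, only, none or still open, it means among the compounds named here.

Notes on the series in a functional assay on PC-3 cells (Homo sapiens) for inhibition, read by MTT assay, with stated times of 18 h and 4 h; a lower number here means a stronger inhibitor, a higher number a weaker inhibitor. Of the compounds shown here, two on the shared core have been read, compound 1 (`CCCCCCCCOP(=O)(O)OCCSC(=S)N1CCCC1`) and compound 2 (`CCCCCCCCOP(=O)(O)OCCSC(=S)N1CCN(C)CC1`). Compound 1 gives > 100000 nM as a limit of the assay. Compound 2 gives > 100000 nM, again a limit, so it stands without a number. The two readings coincide: the limit of > 100000 nM in this assay, at which 2 of the 2 values shown sit. For the measured compounds named here, the one measured step, a step that the two limits leave unreadable from compound 1 to compound 2, offers no size to carry over, and it concerns a different place in the structure. Compound 3 (`CCCCCCOP(=O)(O)OCCSC(=S)N1CCN(C)CC1`) departs from compound 2 by hydrogen in place of ethyl on a saturated chain carbon, six bonds along the chain from an oxygen on an unsaturated carbon. Going by the values given here, no measured step bears on this change. The expectation rests on compound 2 and its limit > 100000 nM alone. No shift beyond the scatter is expected in this assay in either direction, so the expected step is a number no higher from compound 2 to compound 3 (the limit leaves the size open) at most a small one. The estimated value for compound 3 is 100000 nM in an expected range from 40000 nM to 250000 nM and a further limit is likely.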

Compound 3, half-maximal inhibitory concentration: > 100000 nM
Compound 3: a limit, no number; the forecaster's own chance of this, stated with the estimate: 80%; the middle value sits exactly at the limit.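

In this assay no step can be read between compound 2 and compound 3, both being limits of the assay and not numbers: the limit of > 100000 nM in this assay, at which 3 of the 3 values shown sit.

The compounds shown leave open whether the length of the chain or the group on the thiocarbonyl carbon changes inhibition at all.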